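The source may hold more compounds than are shown below. What is called first, only, known or untested is meant among the compounds shown, and "the series" means these compounds.

Measured in a functional assay on MCF7 cells (Homo sapiens) for inhibition, read by MTT assay, with a stated time of 48 h; a lower number here means a stronger inhibitor, a higher number a weaker inhibitor:
compound 1 `O=C(CC(c1ccc(Cl)cc1)C(C(=O)Nc1ccccn1)C(=O)Nc1ccccn1)c1ccccc1` gives 19100 nM
compound 2 `O=C(CC(c1ccc(F)cc1)C(C(=O)Nc1ccccn1)C(=O)Nc1ccccn1)c1ccccc1` gives 20900 nM
compound 3 `O=C(CC(c1ccc(F)cc1)C(C(=O)Nc1ccccn1)C(=O)Nc1ccccn1)c1ccc(F)cc1` gives 23300 nM

Compound 2 stands in a single tight cluster, with compound 1 and compound 3 both within the scatter of it, so the three carry no meaningful rank.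

Compound 4 `O=C(CC(c1c(Cl)cccc1Cl)C(C(=O)Nc1ccccn1)C(=O)Nc1ccccn1)c1ccccc1` carries 2,6-dichlorophenyl in place of 4-fluorophenyl on a saturated chain carbon bound to two saturated chain carbons.

For the measured compounds named here, two measured steps bear on this change. The closer precedent is a 1.1-fold higher number from compound 1 to compound 2 (0.04 log units; within the scatter), with fluoro in place of chloro on the aromatic group that changes here. The other is a 1.1-fold higher number from compound 2 to compound 3 (0.05 log units; within the scatter), with fluoro in place of hydrogen on an aromatic carbon elsewhere in the molecule. Both stay within the scatter. Going by the values given here, no measured compound carries 2,6-dichlorophenyl, so this substitution is untested and the range has to stay wide.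

In this assay no step beyond the scatter is expected, in either direction. The expected step is a 1.1-fold lower number from compound 2 to compound 4 (0.04 log units; within the scatter), which is an estimate only. For compound 4 the estimated value is 19000 nM, with an expected range of 8000 nM to 45000 nM.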

Compound 4, half-maximal inhibitory concentration: 16700 nM
Compound 4: middle estimate off by 1.1-fold (0.06 log units), on the high side, and the stated range covers the measured number.
By their numbers in this assay, from the lowest: compounds 4, 1, 2 and 3 (each within the scatter of the next).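

In this assay the change to 2,6-dichlorophenyl on a saturated chain carbon bound to two saturated chain carbons gives a 1.3-fold lower number from compound 2 to compound 4 (0.10 log units; within the scatter) and also a 1.1-fold lower number from compound 1 to compound 4 (0.06 log units; within the scatter) and both steps stay within the scatter. The earlier compounds shown here only exchanged one halogen for another on this aromatic group, whereas compound 4 alters the number of chlorines and their placement on the ring, and the read-out still shows no change that can be told from repeat noise. So this position accepts 4-fluorophenyl, 4-chlorophenyl and 2,6-dichlorophenyl alike in this cell assay, and nothing available explains why these groups read the same.

All the groups shown at this position are halogen-bearing phenyl rings on the same core, so the series gives no sign yet of what this position would do with a basic amine, a carboxylic acid or a longer alkyl chain in place of the aromatic group. Also open, from the compounds shown here alone, is whether any change at this position can move the number beyond the scatter in either direction, since all four compounds sit in one cluster.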